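The source may hold more compounds than are shown below. What is called first, only, known or untested is meant among the compounds shown, and "the series" means these compounds.

Compound 1 (`CCC(O)[C@@H](CC)Nc1nc(NCc2ccccn2)c2ncn(C(C)C)c2n1`), compound 2 (`CC[C@H](Nc1nc(NCc2ccccn2)c2ncn(C(C)C)c2n1)C(C)O`) and compound 3 (`CC[C@H](Nc1nc(NCc2ccccn2)c2ncn(C(C)C)c2n1)C(C)(C)O`) share one core and differ only in the hydroxy-bearing chain on a nitrogen on an aromatic ring. In a functional assay on A2780 cells (Homo sapiens) for inhibition, read by sulforhodamine B assay, with a stated time of 96 h (a lower number here means a stronger inhibitor of growth, a higher number a weaker inhibitor of growth), compound 1 gives 22000 nM, compound 2 gives 10000 nM and compound 3 gives 19000 nM. Compound 3 therefore stands within the scatter of both other compounds, as shown by a 1.2-fold lower number from compound 1 to compound 3 (0.06 log units; within the scatter) and a 1.9-fold higher number from compound 2 to compound 3 (0.28 log units; within the scatter). Only a 2.2-fold lower number from compound 1 to compound 2 (0.34 log units; beyond the scatter) lies beyond the scatter, and it is modest.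

Compound 4 (`CC[C@H](Nc1nc(NCc2ccccn2)c2ncn(C(C)C)c2n1)C(O)C(C)(C)C`) has not yet been measured. Its difference is 1-hydroxy-2,2-dimethylpropyl in place of 1-hydroxy-1-methylethyl on a saturated chain carbon bound to a nitrogen on an aromatic ring and a saturated chain carbon: 1-hydroxy-2,2-dimethylpropyl stands in place of 1-hydroxy-1-methylethyl on a saturated chain carbon bound to a nitrogen on an aromatic ring and a saturated chain carbon. All three measured steps alter this same part of the molecule, and the largest of them is only a 2.2-fold lower number from compound 1 to compound 2 (0.34 log units; beyond the scatter). For the measured compounds named here, no compound carrying a group as large as the entering one has been measured, so the expectation is an extrapolation. In this assay no step beyond the scatter is expected, in either direction, and the estimate is a 1.1-fold higher number from compound 3 to compound 4 (0.02 log units; within the scatter). For compound 4 the expected value is 20000 nM, with an estimated range from 8000 nM to 50000 nM.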

Compound 4, concentration for 50% growth inhibition: 38000 nM
The estimate for compound 4 lay 1.9-fold (0.28 log units) below the measured number; measured number inside the range.
By their numbers in this assay, from the lowest: compounds 2, 3, 1 and 4 (each within the scatter of the next, the first and the last beyond it).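

In this assay, the larger 1-hydroxy-2,2-dimethylpropyl group on this saturated chain carbon cannot be told apart from the 1-hydroxy-1-methylethyl group, as a 2.0-fold higher number from compound 3 to compound 4 (0.30 log units; within the scatter) shows, nor can the 1-ethyl-2-hydroxy-3,3-dimethylbutyl chain be told apart from the 1-ethyl-2-hydroxybutyl chain, as a 1.7-fold higher number from compound 1 to compound 4 (0.24 log units; within the scatter) shows. For the compounds shown here, the one new step beyond the scatter, and the widest in the set, is tert-butyl in place of methyl on the chain carbon that bears the oxygen, which gives a 3.8-fold higher number from compound 2 to compound 4 (0.58 log units; beyond the scatter) and shows that a large group here can separate two compounds, though only modestly and with compound 3 and compound 1 lying within the scatter of compound 4. Nothing available explains why this step is the widest.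

The compounds shown all keep the hydroxy group on this chain, so they leave open what an amine or a carboxylic acid would do in its place. They also leave open whether a phenyl ring on the same carbon, or a plain chain with no oxygen at all, would move the number further than these changes do.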